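The source may hold more compounds than are shown below. What is called first, only, known or untested is meant among the compounds shown, and "the series" means these compounds.

Measured so far:

- compound 1, `O=c1nc(NO)ccn1[C@@H]1CS[C@H](CO)O1`: 1320000 nM
- compound 2, `Cc1cn([C@@H]2CC[C@H](CO)O2)c(=O)nc1N`: 1550000 nM
- compound 3, `Cc1cn([C@H]2OC[C@H](O)[C@H](O)[C@H]2O)c(=O)nc1N`: > 2000000 nM

In an ADME assay on HepG2 cells (Homo sapiens) for cytotoxicity, read by MTT assay, with a stated time of 3 days (a higher number here means that more compound is tolerated, a lower number that less compound is tolerated), compound 2 gives 1550000 nM. Compound 1 gives 1320000 nM, and the two values sit within the usual scatter of each other, so no order can be read between them. Compound 3 gives only a limit, > 2000000 nM, which tells that its number was not reached in this assay. Thus all three measured compounds are tolerated at very high concentrations, and one of them sits at the ceiling of what could be measured, as the limit of > 2000000 nM in this assay, at which 1 of the 3 values shown sits, shows.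

The unmeasured compound 4, `Cc1cn([C@@H]2C[C@@H](F)[C@H](CO)O2)c(=O)nc1N`, differs from compound 2 in one place: fluoro in place of hydrogen on a saturated ring carbon. The shared core of compound 2 and compound 4 is otherwise unchanged.

Among the measured compounds shown here, no step between measured compounds is available to show what such a change does in this assay. Given that every measured compound sits at or near the top of the range, compound 4 is expected to stay in the same region, with the step of a 1.1-fold lower number from compound 2 to compound 4 (0.04 log units; within the scatter) expected to be no larger than the scatter, in no clear direction. Compound 4 is therefore estimated at 1400000 nM, within a range from 600000 nM to 3000000 nM.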

Compound 4, half-maximal cytotoxic concentration: 1800000 nM
Compound 4: middle estimate off by 1.3-fold (0.11 log units), on the low side; the measured number falls inside the stated range.
By their numbers in this assay, from the lowest: compounds 1, 2 and 4 (each within the scatter of the next). At a limit, above all of these: compound 3.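

In this assay, the set now holds its first step between two compounds that differ in one place: putting fluoro in place of hydrogen on a saturated ring carbon, next to the ring atom that bears a hydroxymethyl group, comes out as a 1.2-fold higher number from compound 2 to compound 4 (0.06 log units; within the scatter). A step of this size cannot be told from repeat-to-repeat variation, so at this position the change shows no measurable effect on how much compound the cells tolerate, in either direction. Compound 3 gives a limit and not a number, which marks a ceiling on what this read-out reports: the limit of > 2000000 nM in this assay, at which 1 of the 4 values shown sits.

What this one step cannot say is whether the position is insensitive to change in general, since a single small atom was swapped for hydrogen and the result applies to that swap alone. An amine or a methoxy group on the same ring carbon might behave differently, and the compounds shown also leave open whether fluoro on another carbon of this ring would give a step beyond the scatter.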